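The source may report more compounds than this note shows. Statements on the series, on what has been measured and on what is new or still open speak of the compounds shown alone.

Measured compounds:

Compound 1, `O=C(NCCCCc1ccccc1)n1c(-c2ccc(Cl)cc2)coc1=O`, 5 nM
Compound 2, `O=c1[nH]cc(-c2ccccc2)o1`, "not active" (no number reported)
Compound 3, `O=C(NCCCCc1ccccc1)n1cc(-c2ccc(Cl)cc2)oc1=O`, 83 nM

These three compounds were tested in an assay on isolated protein for inhibition of acid ceramidase (Homo sapiens), read by LC-MS, with a stated time of 1 h; a lower number here means a stronger inhibitor, a higher number a weaker inhibitor. Compound 3, with 83 nM, holds the higher of the two numbers reported; compound 1 sits well below it, and the gap between the two lies beyond the scatter of the assay. Compound 2 is the smaller fragment without the long side chain, and in this assay compound 2 gives "not active" (no number reported).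

The next compound, compound 4, has the structure `COc1cccc(-c2cn(C(=O)NCCCCc3ccccc3)c(=O)o2)c1`. It keeps the core and the side chain of compound 3 and differs in one place: 3-methoxyphenyl in place of 4-chlorophenyl on an aromatic carbon. Among the measured compounds shown here, no measured pair shows this particular exchange, so the expected step from compound 3 to compound 4 rests on the structural change alone; a modest step is expected, most likely a small loss of potency, with the chance that it stays within the scatter. The estimated step is a 1.8-fold higher number from compound 3 to compound 4 (0.26 log units; within the scatter). Compound 4 is therefore expected to give about 150 nM in this assay, with a range from 40 nM to 600 nM.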

Compound 4, half-maximal inhibitory concentration: 341 nM
The estimate for compound 4 lay 2.3-fold (0.36 log units) below the measured number; the range from low to high includes it.
By their numbers in this assay, from the lowest: compound 1; then compound 3; then compound 4.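

In this assay this position proves sensitive to the group it carries: 3-methoxyphenyl in place of 4-chlorophenyl gives a 4.1-fold higher number from compound 3 to compound 4 (0.61 log units; beyond the scatter) on the same core and side chain. The aromatic carbon next to the ring oxygen therefore does not treat these two substituted phenyl groups alike, although the change still leaves a measurable number rather than "not active". Nothing measured here gives a reason for this rise.

The exchange swaps chlorine for methoxy and moves the substituent on the phenyl ring at the same time, so this one step cannot say which of the two matters. A 3-chlorophenyl or a 4-methoxyphenyl at this carbon would separate them, and an unsubstituted phenyl would show what either substituent adds.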